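Swapping the ketone-side trimethoxyphenyl for a plain phenyl

The compounds below may be only part of what the source reports. "The series", "measured", "known", "first", "only" and "open" are said of these compounds alone.

Three chalcone-like compounds built on a shared core have been tested in a functional assay on MDA-MB-231 cells (Homo sapiens) for antiproliferative activity, read by MTT assay, with a stated time of 24 h; a lower number here means a stronger inhibitor, a higher number a weaker inhibitor. Compound 1 `COc1cc(C(=O)/C=C/c2cc(-c3cc(OC)c(OC)c(OC)c3)n3nc(-c4ccccc4)cc3n2)cc(OC)c1OC` gives 24300 nM in this assay, the highest number of the three measured. Compound 2 `COc1ccc(-c2cc(/C=C/C(=O)c3cc(OC)c(OC)c(OC)c3)nc3cc(-c4ccccc4)nn23)cc1OC` differs from it only by a hydrogen in place of a methoxy on an aromatic carbon, and compound 2 gives 4700 nM; that step, a 5.2-fold lower number from compound 1 to compound 2 (0.71 log units; beyond the scatter), is modest but clear. Compound 3 `COc1ccc(-c2cc(/C=C/C(=O)c3ccc(C)c(C)c3)nc3cc(-c4ccccc4)nn23)cc1OC` carries a 3,4-dimethylphenyl instead of the 3,4,5-trimethoxyphenyl on the carbonyl carbon, and compound 3 gives 11500 nM, so that a 2.4-fold higher number from compound 2 to compound 3 (0.39 log units; beyond the scatter).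

Compound 4 `COc1cc(-c2cc(/C=C/C(=O)c3ccccc3)nc3cc(-c4ccccc4)nn23)cc(OC)c1OC` arises from compound 1 by the change (phenyl in place of 3,4,5-trimethoxyphenyl on a carbonyl carbon). For the measured compounds named here, the only measured step touching that position is the one from compound 2 to compound 3, in which replacing the 3,4,5-trimethoxyphenyl on the carbonyl carbon raised the number. Removing all three methoxy groups at once is a larger change of the same kind, so a rise of at least similar size is expected for compound 4, namely a 1.9-fold higher number from compound 1 to compound 4 (0.27 log units; within the scatter). Compound 4 is therefore expected to give about 45000 nM in this assay, within a range of 15000 nM to 130000 nM.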

Compound 4, half-maximal inhibitory concentration: 15800 nM
The estimate for compound 4 lay 2.8-fold (0.45 log units) above the measured number; low and high end bracket the measured number.
By their numbers in this assay, from the lowest: compound 2; then compounds 3, 4 and 1 (each within the scatter of the next, the first and the last beyond it).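

In this assay, putting phenyl in place of 3,4,5-trimethoxyphenyl on the carbonyl carbon gives a 1.5-fold lower number from compound 1 to compound 4 (0.19 log units; within the scatter), so a group of 12 heavy atoms and 3 hydrogen-bond acceptors gives way to one of 6 heavy atoms and no acceptors without a difference this assay can separate from scatter. On the core of compound 1, then, the methoxy groups at this position are not needed to keep the number where it stands, whereas the one earlier replacement here, a 2.4-fold higher number from compound 2 to compound 3 (0.39 log units; beyond the scatter), lay beyond the scatter, so this position does not behave alike in these two pairs. No measurement shown here accounts for that contrast.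

The two pairs differ both in the group that enters and in the aryl group elsewhere on the core, so the compounds shown leave open which of these matters, and whether phenyl would also match the 3,4,5-trimethoxyphenyl of compound 2. They also leave open what a ring bearing an amine or a carboxylic acid would do on this carbonyl carbon, where only aryl groups with methoxy or methyl substituents, or none, appear so far.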